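This account rests on a few compounds, and the source may have more. Where it says the series, first, only, none or still open, it means among the compounds named here.

Compound 1, `Cc1ccc(-c2ccc(C)n2-c2ccc(-c3nc4ccc(F)cc4s3)cc2)cc1`, gives 2150 nM in a functional assay on MCF7 cells (Homo sapiens) for cytotoxicity, read by sulforhodamine B assay, with a stated time of 48 h; a lower number here means a stronger inhibitor of growth, a higher number a weaker inhibitor of growth. Compound 2, `Cc1ccc(-c2ccc(F)cc2)n1-c1ccc(-c2nc3ccc(F)cc3s2)cc1`, carries the change fluoro in place of methyl on an aromatic carbon relative to compound 1; in this assay compound 2 gives 1790 nM. The resulting step, a 1.2-fold lower number from compound 1 to compound 2 (0.08 log units; within the scatter), is too small to read as a change in growth inhibition. Compound 3, `COc1cc2nc(-c3ccc(-n4c(C)ccc4-c4ccc(C)cc4)cc3)sc2c(OC)c1OC`, is built on a different core; the difference between the two cores is not broken down here. In this assay compound 3 gives 2910 nM, a number that sits within the scatter of both compound 1 and compound 2.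

Compound 4, `COc1cc2nc(-c3ccc(-n4c(C)ccc4-c4ccc(F)cc4)cc3)sc2c(OC)c1OC`, has not yet been measured. It differs from compound 3 by fluoro in place of methyl on an aromatic carbon, the same change that separates compound 2 from compound 1, at the same kind of place. Given that compound 1 to compound 2 moved only by a 1.2-fold lower number from compound 1 to compound 2 (0.08 log units; within the scatter), the expected step from compound 3 to compound 4 is a 1.2-fold lower number from compound 3 to compound 4 (0.08 log units; within the scatter), a shift within the scatter. On that basis the estimated value for compound 4 in this assay is 2400 nM, with a range from 1200 nM to 4800 nM.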

Compound 4, concentration for 50% growth inhibition: 2670 nM
Compound 4: the middle estimate sits 1.1-fold (0.05 log units) below what was measured; the range from low to high includes it.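

In this assay, fluoro in place of methyl on the aromatic carbon, the change of 4-methylphenyl to 4-fluorophenyl, gives a 1.1-fold lower number from compound 3 to compound 4 (0.04 log units; within the scatter), too small to read as a change in growth inhibition. Set beside the earlier step, the change looks the same on the two cores: the same change on two cores in this assay, a 1.2-fold lower number (0.08 log units; within the scatter) from compound 1 to compound 2 and a 1.1-fold lower number (0.04 log units; within the scatter) from compound 3 to compound 4, 1.1-fold (0.04 log units) apart, within the scatter of two such steps. This shows that on these two cores the change leaves no readable mark in this assay, and that a null result carried over from one core to the other, but with neither step beyond the scatter, it does not show that a real shift in growth inhibition can be carried across cores, nor that the same would hold on any further core.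

The compounds shown hold only methyl and fluoro at this place, so what a chloro group, an amine or a carboxylic acid would do there stays open. Also open, as far as these compounds go, is whether the change stays as silent on the two cores in any assay other than this assay.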